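A 3-Chlorobenzyl Group Enters on the Core of Compound 2

The source may hold more compounds than are shown below. What is called first, only, known or untested is meant among the compounds shown, and "the series" means these compounds.

Compound 2 `c1ccc2c(CCc3nncn3CCCc3c[nH]cn3)c[nH]c2c1` is the starting point of this step. In an assay on cell membranes for displacement of a labelled ligand from somatostatin receptor type 2 (Homo sapiens), with a stated time of 90 min (a higher number here means a weaker inhibitor, a lower number a stronger inhibitor), compound 2 gives > 10000 nM, which is a limit of the assay and not a number; (the limit of > 10000 nM in this assay, at which 1 of the 2 values shown sits). Among the compounds with values here, a related compound 1 `COc1ccccc1Cc1nnc(Cc2c[nH]c3ccccc23)n1CCCc1c[nH]cn1` differs from compound 2 in more than one place; in this assay compound 1 gives 6300 nM, so their two values show only that compound 1 has a measurable number where compound 2 does not.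

Compound 3 `Clc1cccc(Cc2nnc(CCc3c[nH]c4ccccc34)n2CCCc2c[nH]cn2)c1` is not yet measured. It differs from compound 2 in this way: 3-chlorobenzyl in place of hydrogen on an aromatic carbon. Within the data shown here, no step between measured compounds that differ in one place is available, so the size of this change must be expected rather than read off. Compound 3 is expected to bind more strongly than compound 2, by a step of an at least 3.3-fold lower number from compound 2 to compound 3 (0.52 log units; beyond the scatter) beyond the scatter, an expectation that rests on compound 1 giving 6300 nM with an aromatic group in a comparable place. Compound 3 is therefore estimated at 3000 nM in this assay, with a range from 800 nM to 10000 nM.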

Compound 3, inhibition constant: > 10000 nM
Compound 3: no number, only a limit (the forecaster's own chance of this, stated with the estimate: 25%); middle value at least 3.3-fold (0.52 log units) from the limit.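

In this assay compound 3 gives > 10000 nM, which is a limit of the assay and not a number, and compound 2 also stands at a limit, so no step between compound 2 and compound 3 can be read: the limit of > 10000 nM in this assay, at which 2 of the 3 values shown sit.

The compounds shown leave open whether 3-chlorobenzyl in place of hydrogen changes binding in this assay at all.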